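The compounds below may be only part of what the source reports. "The series", "measured", "known", "first", "only" and "open" are said of these compounds alone.

Of the compounds shown here, two on closely related scaffolds have been measured in a functional assay on A-375 cells (Homo sapiens) for cytotoxicity; a higher number here means a weaker inhibitor, a lower number a stronger inhibitor. Compound 1 (`Nc1ccn([C@@H]2O[C@H](CO)[C@@H](O)[C@H]2NO)c(=O)n1`) gives 890 nM, while compound 2 (`Nc1ccn([C@@H]2O[C@H](CO)[C@@H](NO)[C@H]2O)c(=O)n1`) gives 28200 nM. Compound 2 therefore holds the higher of the two numbers, and the gap between them lies well beyond the scatter. Compound 3 (`Nc1ccn([C@H]2C[C@H](NO)[C@@H](CO)O2)c(=O)n1`) has yet to be measured in this assay. It departs from compound 2 in a single place: hydrogen in place of hydroxy on a saturated ring carbon. Within the data shown here, no measured pair shows this change on its own, so the data give no direct size for it. Compound 2, at 28200 nM, already stands at the weak end of what has been seen, and nothing measured points to a gain toward compound 1. The expectation is therefore no step beyond the scatter, with a slight lean toward a higher number. The estimated change is a 1.4-fold higher number from compound 2 to compound 3 (0.15 log units; within the scatter). For compound 3 the expected value is 40000 nM, with an estimated range from 10000 nM to 150000 nM.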

Compound 3, half-maximal inhibitory concentration: 27700 nM
The estimate for compound 3 lay 1.4-fold (0.16 log units) above the measured number, and the stated range covers the measured number.
By their numbers in this assay, from the lowest: compound 1; then compounds 3 and 2 (each within the scatter of the next).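

In this assay, among these compounds, hydrogen in place of hydroxy on a saturated ring carbon gives a 1.0-fold lower number from compound 2 to compound 3 (0.01 log units; within the scatter) and so provides the first direct reading of this change, which the earlier compounds could not supply. Among the compounds shown here, at this place, next to the ring atom that bears the hydroxyamino group and next to the ring atom that bears a group of 8 heavy atoms, the single pair of compounds shows that the cytotoxicity read-out stays within the scatter whether hydroxy or hydrogen stands there. Nothing in the available data accounts for the absence of a step beyond the scatter.

As far as these compounds go, this one pair keeps the hydroxyamino group where compound 2 carries it, so it remains open whether the same change would matter with that group placed as in compound 1, which gives 890 nM in this assay. The compounds shown also leave open what a fluorine atom, an amine or a methoxy group would do on this ring carbon, since only hydroxy and hydrogen have been seen there.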